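The compounds below may be only part of what the source reports. "The series", "measured", "known", "first", "only" and "open" are said of these compounds alone.

Measured so far:
compound 1, `O=C1/C(=C\c2c(Cl)cccc2Cl)c2ccccc2N1c1c(Cl)cccc1Cl` — in a functional assay on B16-F10 cells (Homo sapiens) for cytotoxicity against B16-F10 (Mus musculus), read by MTT assay, with a stated time of 72 h (on this read-out lower numbers stand for an effect already at smaller amounts and higher numbers for an effect only at larger amounts of compound), compound 1 gives > 100 ug/mL, which is a limit of the assay and not a number.
compound 2, `O=C1/C(=C\c2cccc(Br)c2)c2ccccc2N1c1c(Cl)cccc1Cl` — in this assay compound 2 gives 8 ug/mL.
compound 3, `O=C1/C(=C\c2ccccc2[N+](=O)[O-])c2ccccc2N1c1c(Cl)cccc1Cl` — in this assay compound 3 gives > 100 ug/mL, again a limit of the assay.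

Compound 3 therefore stands at the top of the numbers shown, together with compound 1: the limit of > 100 ug/mL in this assay, at which 2 of the 3 values shown sit. Among the compounds with values here, the step that the two limits leave unreadable from compound 1 to compound 3 cannot be sized, and compound 2 is the only compound with a readable number.

Compound 4, `O=C1/C(=C\c2ccc(Cl)cc2)c2ccccc2N1c1c(Cl)cccc1Cl`, differs from compound 3 by 4-chlorophenyl in place of 2-nitrophenyl on a double-bonded chain carbon bound to a double-bonded ring carbon. Within the data shown here, two measured steps bear on this. The step of an at least 12-fold higher number from compound 2 to compound 3 (1.09 log units; beyond the scatter) shows that replacing the single-halogen 3-bromophenyl with the 2-nitrophenyl pushed the number from a readable value up to the limit; the step of an at least 12-fold lower number from compound 1 to compound 2 (1.09 log units; beyond the scatter) shows the opposite move, from 2,6-dichlorophenyl to 3-bromophenyl, giving a large drop. Compound 4 carries a single halogen on the phenyl, as compound 2 does, so the step from compound 3 to compound 4 is expected to be a large lowering, an at least 6.6-fold lower number from compound 3 to compound 4 (0.82 log units; beyond the scatter), of roughly the size seen into compound 2. Compound 4 is thus expected to give about 15 ug/mL in this assay, within 4 ug/mL to 60 ug/mL.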

Compound 4, concentration for half-maximal effect: > 100 ug/mL
Compound 4: no number, only a limit; the forecaster's own chance of this, stated with the estimate: 25%; at least 6.6-fold (0.82 log units) between middle value and limit.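

In this assay compound 4 gives > 100 ug/mL, which is a limit of the assay and not a number, and it joins the top of the values shown: the limit of > 100 ug/mL in this assay, at which 3 of the 4 values shown sit. A single halogen on the phenyl therefore does not by itself give a readable number at this place, on a double-bonded chain carbon bound to a double-bonded ring carbon: 4-chlorophenyl in place of 3-bromophenyl gives an at least 12-fold higher number from compound 2 to compound 4 (1.09 log units; beyond the scatter), so the readable value of compound 2 depends on more than having one halogen there. The steps into compound 4 from compound 1 and compound 3 join two limits and cannot be read.

Compound 2 and compound 4 differ both in the halogen and in where it sits on the phenyl, and the compounds shown do not separate the two; a 3-chlorophenyl and a 4-bromophenyl would do so. Going by these compounds, it also remains open whether a phenyl carrying an amine or a carboxylic acid at this place would give a readable number in this assay.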